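Removing the Chloro Group of Compound 1: Expected Hemolysis

A few compounds are considered here, and "the series" means these few. Any claim that something is new, unique, unknown or untested is made for them only; others in the source may bear on it.

Measured compounds:
Compound 1, `N=C(N)c1ccc(-c2ccc(-c3ccc(Cl)cc3)o2)o1`: 41.3%
Compound 2, `N=C(N)c1ccc(-c2ccc(-c3ccccc3)s2)s1`: 15.3%

Going by the values given here, in an ADME assay on cells (Erythrocyte, Homo sapiens) for activation, read by hemolysis, with a stated time of 30 min, tested at 2.5 mM (a lower number here means a weaker effect, a higher number a stronger effect of the compound at the concentration tested), compound 1 gives 41.3%, the higher of the two numbers measured so far. Compound 2 gives 15.3%, a number lower by a margin beyond the usual scatter. Compound 2 differs from compound 1 in more than one place, so the two values show only that the measured set spans a sizeable range; they isolate no single change.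

Compound 3, `N=C(N)c1ccc(-c2ccc(-c3ccccc3)o2)o1`, is not yet measured. It differs from compound 1 in one place: hydrogen in place of chloro on an aromatic carbon. Among the compounds with values here, no step between measured compounds follows this change on its own. Compound 2 also carries hydrogen in place of chloro, but its other differences from compound 1 leave the effect of the chloro group unresolved. The step from compound 1 to compound 3 in this assay is expected to be downward and of moderate size, and the expected step is a number 13.3 percentage points lower from compound 1 to compound 3 (beyond the scatter). Compound 3 is accordingly estimated at 28% in this assay, with an expected range from 10% to 48%.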

Compound 3, a percentage reported as activity, at one concentration (the size of the read-out at that concentration, not a potency): 7%
Estimate against measurement, compound 3: 21 percentage points above; the whole stated range lies above it.
By their numbers in this assay, from the lowest: compounds 3 and 2 (each within the scatter of the next); then compound 1.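

Going by these compounds alone, the step isolates the chloro group for the first time: in this assay, hydrogen in place of chloro on an aromatic carbon of the six-membered aromatic ring of carbon only, para to a large group, gives a number 34.3 percentage points lower from compound 1 to compound 3 (beyond the scatter). This position is therefore not indifferent in this read-out, as one chlorine atom leaving the otherwise unchanged structure of compound 1 is enough to produce a large step, something the earlier pair, differing in more than one place, could not show. Nothing at hand says why the read-out responds to this change.

As far as these compounds go, it remains open whether this response is specific to chloro or would also appear with fluoro, methyl, methoxy, an amine or a carboxylic acid at the same place on the core of compound 3. From the compounds shown here alone, it also remains open whether adding chloro at the matching place on compound 2 would bring a step of similar direction and size.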